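The compounds below may be only part of what the source reports. "The series", "measured", "known", "first", "only" and "open" are said of these compounds alone.

Within the data shown here, compound 1, with the structure `O=C1N=C(O)S/C1=C\c1ccc(OCCC2CCCCC2)cc1Cl`, is one of three compounds measured in an assay for inhibition of 15-hydroxyprostaglandin dehydrogenase [NAD(+)] (Homo sapiens), read by fluorescence and spectrophotometry; a lower number here means a stronger inhibitor, a higher number a weaker inhibitor. In this assay compound 1 gives 13 nM, the lowest of the three numbers. Compound 3, `O=C1NC(=O)/C(=C/c2ccc(OCCOC3CCCCC3)c(Cl)c2)S1`, stands closest to it: in this assay compound 3 gives 20 nM, a number that lies within the scatter of repeated measurements of compound 1, so no order between compound 1 and compound 3 can be read from these two values. Compound 2, `O=C1NC(=O)/C(=C/c2ccc(OCc3ccc([N+](=O)[O-])cc3)c(Cl)c2)S1`, is the furthest away: in this assay compound 2 gives 930 nM, a gap to compound 1 that lies well beyond the scatter.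

The unmeasured compound 4, `O=C1N=C(O)S/C1=C\c1ccc(OCCCc2ccccc2)cc1Cl`, differs from compound 1 in a single place: benzyl in place of cyclohexyl on a saturated chain carbon, two bonds along the chain from an oxygen on an aromatic ring. Among the measured compounds shown here, no pair of measured compounds shows this exact exchange, so the size of the step has to be judged from the structures alone. Since the shared core and the chain that carries the ring are kept, the step from compound 1 to compound 4 is expected to be small, with at most a modest move toward a higher number, as a 1.9-fold higher number from compound 1 to compound 4 (0.28 log units; within the scatter). Compound 4 is therefore estimated at 25 nM in this assay, within a range of 8 nM to 80 nM.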

Compound 4, half-maximal inhibitory concentration: 52 nM
Compound 4: middle estimate off by 2.1-fold (0.32 log units), on the low side; low and high end bracket the measured number.
By their numbers in this assay, from the lowest: compounds 1 and 3 (each within the scatter of the next); then compound 4; then compound 2.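

Among these compounds, this is the first exchange that can be read on its own. In this assay, benzyl in place of cyclohexyl on a saturated chain carbon, two bonds along the chain from an oxygen on an aromatic ring, gives a 4.0-fold higher number from compound 1 to compound 4 (0.60 log units; beyond the scatter), so this place on the chain is not indifferent to what it carries, and the step lies beyond the scatter even though neither group has hydrogen-bond donors, hydrogen-bond acceptors or a net charge. The single step changes two things together, a non-aromatic ring of carbon for an aromatic one and 6 heavy atoms for 7, and nothing shown gives a reason for its size.

The compounds shown leave open which of these two changes carries the step, and cyclohexylmethyl or phenyl on the same chain carbon would separate the ring from the added carbon. On these data alone, whether this place accepts a group other than a carbon ring, such as an amine or a carboxylic acid, also remains open.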